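Methyl substitution on the pentenoic acid analogue

The source may hold more compounds than are shown below. What is called first, only, known or untested is meant among the compounds shown, and "the series" means these compounds.

The series shares one core carrying a (pyridin-3-yl)methyl group, a chlorophenylsulfonamide and an acid-bearing side chain. Compound 1 `O=C(O)CCc1cc(Cc2cccnc2)cc2c1CCC(NS(=O)(=O)c1ccc(Cl)cc1)C2` gives 1100 nM in an assay on blood with Thromboxane-A synthase (Homo sapiens) as the target; on this read-out higher numbers stand for weaker inhibition and lower numbers for stronger inhibition. Compound 2 `Cc1c(Cc2cccnc2)cc2c(c1CCC(=O)O)CCC(NS(=O)(=O)c1ccc(Cl)cc1)C2`, which carries a methyl on the core, gives 850 nM in this assay; the step of a 1.3-fold lower number from compound 1 to compound 2 (0.11 log units; within the scatter). Compound 3 `O=C(O)CCC/C=C/c1cc(Cc2cccnc2)cc2c1CCC(NS(=O)(=O)c1ccc(Cl)cc1)C2` carries the longer unsaturated acid chain instead. In this assay compound 3 gives > 5000 nM, which is a limit of the assay and not a number. Compound 3 therefore sits at the upper end of the numbers shown, at the limit (the limit of > 5000 nM in this assay, at which 1 of the 3 values shown sits), and the step of an at least 4.5-fold higher number from compound 1 to compound 3 (0.65 log units; beyond the scatter).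

Compound 4 `Cc1c(Cc2cccnc2)cc2c(c1/C=C/CCCC(=O)O)CCC(NS(=O)(=O)c1ccc(Cl)cc1)C2` differs from compound 3 by methyl in place of hydrogen on an aromatic carbon. Among the measured compounds shown here, the only measured step bearing on this change is the one from compound 1 to compound 2, where a 1.3-fold lower number from compound 1 to compound 2 (0.11 log units; within the scatter). The same change applied to compound 3 is therefore expected to move this assay by no more than the scatter, with the expected step that the limit leaves unreadable from compound 3 to compound 4. Compound 4 is expected to give about 6000 nM in this assay, within a range from 3000 nM to 15000 nM, and most likely to be reported again only as a limit.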

Compound 4, half-maximal inhibitory concentration: 2900 nM
Beside the measured number, compound 4's estimate is 2.1-fold (0.32 log units) above it; measured number below the stated range.
By their numbers in this assay, from the lowest: compounds 2 and 1 (each within the scatter of the next); then compound 4. At a limit, above all of these: compound 3.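

With the 5-carboxypent-1-en-1-yl group on the core, methyl in place of hydrogen gives a readable number in this assay, whereas the value for compound 3 is only a limit: the limit of > 5000 nM in this assay, at which 1 of the 4 values shown sits. The step reads an at least 1.7-fold lower number from compound 3 to compound 4 (0.23 log units; that floor lies within the scatter), so its floor does not separate it from the scatter, and the change is not shown to behave differently with this chain than with the 2-carboxyethyl group: the same change on two cores in this assay, a 1.3-fold lower number (0.11 log units; within the scatter) from compound 1 to compound 2 and an at least 1.7-fold lower number (0.23 log units; that floor lies within the scatter) from compound 3 to compound 4; the limit leaves it open whether they differ. With the methyl present on both compounds, the chain change now has a measured number at each end, a 3.4-fold higher number from compound 2 to compound 4 (0.53 log units; beyond the scatter), so the higher number with the 5-carboxypent-1-en-1-yl group holds with the methyl as well as without it: the same change on two cores in this assay, an at least 4.5-fold higher number (0.65 log units; beyond the scatter) from compound 1 to compound 3 and a 3.4-fold higher number (0.53 log units; beyond the scatter) from compound 2 to compound 4; the limit leaves it open whether they differ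

On these data alone, the true size of the methyl step on compound 3 remains open, since only its floor can be read, and so does any difference from the same step on compound 1. Also open, as far as these compounds go, is whether ethyl or chlorine on this aromatic carbon, or a saturated 5-carboxypentyl chain in place of the 5-carboxypent-1-en-1-yl group, would move the number further in either direction.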